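This account rests on a few compounds, and the source may have more. Where it says the series, first, only, none or still open, it means among the compounds named here.

Within the data shown here, in an ADME assay on HepG2 2.2.15 cells (Homo sapiens) for cytotoxicity (on this read-out higher numbers stand for lower toxicity in this test and lower numbers for higher toxicity in this test), compound 1 (`CCCC(=O)OCCc1c(-c2ccccc2Cl)c2cc(Cl)ccc2[nH]c1=O`) gives 52000 nM and compound 2 (`CC(=O)N1CCC(C(=O)OCCc2c(-c3ccccc3Cl)c3cc(Cl)ccc3[nH]c2=O)CC1`) gives 82000 nM, so compound 2 stands within the scatter of the only other measured number. Compound 3 (`O=C(CN1C(=O)c2ccccc2C1=O)OCCc1c(-c2ccccc2Cl)c2cc(Cl)ccc2[nH]c1=O`) differs from compound 2 on a carbonyl carbon: a group of 12 heavy atoms (9 carbon, 1 nitrogen, 2 oxygen; one five-membered non-aromatic ring with 1 hetero atom, one six-membered aromatic ring of carbon only) in place of a group of 9 heavy atoms (7 carbon, 1 nitrogen, 1 oxygen; one six-membered non-aromatic ring with 1 hetero atom), on a carbonyl carbon. Among the measured compounds shown here, one measured step bears on this change, a replacement on that same carbonyl carbon: a 1.6-fold higher number from compound 1 to compound 2 (0.20 log units; within the scatter). On that evidence, no change beyond the scatter is expected in this assay. The expected step is a 1.2-fold lower number from compound 2 to compound 3 (0.07 log units; within the scatter). Compound 3 is estimated at 70000 nM, with an expected range of 30000 nM to 150000 nM.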

Compound 3, half-maximal cytotoxic concentration: 960000 nM
Beside the measured number, compound 3's estimate is 14-fold (1.14 log units) below it; the whole stated range lies below it.
By their numbers in this assay, from the lowest: compounds 1 and 2 (each within the scatter of the next); then compound 3.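

In this assay, among these compounds, the earlier replacement on this carbonyl carbon stayed within the scatter, so the place had not yet been seen to move the read-out. The group with a five-membered non-aromatic ring and a six-membered aromatic ring now gives a 12-fold higher number from compound 2 to compound 3 (1.07 log units; beyond the scatter) and an 18-fold higher number from compound 1 to compound 3 (1.27 log units; beyond the scatter) in the same series, so not every replacement here leaves the number unchanged. Nothing available bears on the reason for this step. The compounds shown leave open which of the two rings carries the step, and how an amine or a carboxylic acid would read on this carbonyl carbon.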